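Methoxycarbonyl to ethoxycarbonyl on compound 1

The source may hold more compounds than are shown below. What is called first, only, known or untested is meant among the compounds shown, and "the series" means these compounds.

In a functional assay on the whole organism for agonist activity, with Mus musculus as the target (a higher number here means that more compound is needed for the effect, a lower number that less compound is needed), compound 1 (`COC(=O)N(C)CC#CCn1ccnc1`) gives 4.5 mg/kg as the lowest of the two numbers available. Compound 3 (`COC(=O)N(C)CC#CCN(C)C`) is the nearest at 14.3 mg/kg and stands clearly higher. Compound 2 (`COC(=O)N(C)CC#CCn1cncc1C`) gives > 100 mg/kg as a limit of the assay and not a number.

Compound 4 (`CCOC(=O)N(C)CC#CCn1ccnc1`) differs from compound 1 by methyl in place of hydrogen on a saturated chain carbon bound to an oxygen next to a carbonyl group. Methoxycarbonyl thus becomes ethoxycarbonyl. Among the measured compounds shown here, no measured step covers this place, so the evidence is indirect. The closest in kind is methyl in place of hydrogen on an aromatic carbon, which gives an at least 22-fold higher number from compound 1 to compound 2 (1.34 log units; beyond the scatter) as a large step. Dimethylamino in place of 1H-imidazol-1-yl gives a 3.2-fold higher number from compound 1 to compound 3 (0.50 log units; beyond the scatter) as a modest one.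

Both steps away from compound 1 raise the number, but neither was made at the changing place, so only part of their size carries over. A modest rise is expected, with no change beyond the scatter also possible. The expected step is a 2.4-fold higher number from compound 1 to compound 4 (0.39 log units; beyond the scatter) in this assay as a working figure. The estimated value for compound 4 is 11 mg/kg with 3 mg/kg to 50 mg/kg as the expected range.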

Compound 4, dose for half-maximal effect: > 100 mg/kg
Compound 4: no number, only a limit; the forecaster's own chance of this, stated with the estimate: 15%; middle value at least 9.0-fold (0.95 log units) from the limit.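

Methoxycarbonyl is not a freely changeable end of compound 1: in this assay, methyl in place of hydrogen on a saturated chain carbon bound to an oxygen next to a carbonyl group gives an at least 22-fold higher number from compound 1 to compound 4 (1.34 log units; beyond the scatter). The sensitivity to one added methyl therefore extends to this place as well as to the aromatic carbon, where the change gives an at least 22-fold higher number from compound 1 to compound 2 (1.34 log units; beyond the scatter), and the exchange of 1H-imidazol-1-yl for dimethylamino, which gives a 3.2-fold higher number from compound 1 to compound 3 (0.50 log units; beyond the scatter), stays readable by comparison. The value of compound 4 is a limit of the assay and not a number, so the step gives only a floor, and its size cannot be ranked against the step to compound 2: the limit of > 100 mg/kg in this assay, at which 2 of the 4 values shown sit.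

As far as these compounds go, it remains open whether any other group at this place keeps a readable number, such as an amide in place of the ester, a carboxylic acid or a longer chain such as propoxycarbonyl. From the compounds shown here alone, it is equally open whether ethoxycarbonyl behaves the same way when dimethylamino replaces 1H-imidazol-1-yl on the core of compound 1.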